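The compounds below may be only part of what the source reports. "The series", "measured", "known", "first", "only" and "open" are said of these compounds alone.

Working notes on the series. Three compounds have numbers in a functional assay (Cavia porcellus) with sulfonylurea receptors; K-ATP channels (Homo sapiens) as the target; a lower number here means a stronger inhibitor, a higher number a weaker inhibitor. Compound 1 `CC(O)(C(=O)Nc1ccc(S(=O)(=O)c2ccccc2F)cc1)C(F)(F)F` gives 1300 nM. Compound 2 `CC(O)(C(=O)Nc1ccc(S(=O)(=O)c2ccccc2)c(O)c1)C(F)(F)F` gives 430 nM, the lowest of the three numbers; the nearest to it is compound 1 and the furthest compound 3, both gaps beyond the scatter. Compound 3 `CC(O)(C(=O)Nc1ccc(S(=O)(=O)c2ccccc2O)cc1)C(F)(F)F` gives 3090 nM. For the measured compounds named here, only one pair differs in a single place: hydroxy in place of fluoro on an aromatic carbon, which gave a 2.4-fold higher number from compound 1 to compound 3 (0.38 log units; beyond the scatter).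

Compound 4 `Cc1cc(NC(=O)C(C)(O)C(F)(F)F)ccc1S(=O)(=O)c1ccccc1` awaits measurement in this assay. It differs from compound 2 by methyl in place of hydroxy on an aromatic carbon. Going by the values given here, no measured step carries this change; the step from compound 1 to compound 3 concerns the other ring and so does not bear on it directly. Among the compounds with values here, what the numbers do show is that compound 2, the only compound with a hydroxy on this ring, sits lowest, while compound 1, which lacks it, gives 1300 nM. Losing the hydroxy is therefore expected to cost something, though a methyl in its place is an untested substitution, so the expected step is set as a modest rise: a 2.1-fold higher number from compound 2 to compound 4 (0.32 log units; beyond the scatter). For compound 4 the estimate in this assay is 900 nM, with a range from 350 nM to 2500 nM.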

Compound 4, half-maximal inhibitory concentration: 1600 nM
Compound 4: middle estimate off by 1.8-fold (0.25 log units), on the low side; the range from low to high includes it.
By their numbers in this assay, from the lowest: compound 2; then compounds 1, 4 and 3 (each within the scatter of the next, the first and the last beyond it).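

In this assay, for the compounds shown here, methyl in place of hydroxy on this aromatic carbon gives the first measured step at this position, a 3.7-fold higher number from compound 2 to compound 4 (0.57 log units; beyond the scatter), so the low number of compound 2 does not survive this single change. The heavy-atom count stays the same, while the hydrogen-bond donor and acceptor counted for the hydroxy are absent from the methyl, which shows that a swap of one heavy atom at this place, ortho to a group of 9 heavy atoms and meta to a large group, is enough for a step beyond the scatter. No measurement at hand gives a reason for this step.

With only this one step at the position, the compounds shown do not separate the loss of the hydroxy from the arrival of the methyl. A plain hydrogen, a methoxy or an amine on the same carbon, with the rest of compound 2 unchanged, would show whether the number follows the hydroxy itself or depends on the group that replaces it.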